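The compounds below may be only part of what the source reports. "The series", "measured", "known", "first", "only" and "open" are said of these compounds alone.

Of the compounds shown here, two have so far been measured in a functional assay on T47D cells (Homo sapiens) for inhibition, read by sulforhodamine B assay, with a stated time of 48 h; a higher number here means a weaker inhibitor of growth, a lower number a stronger inhibitor of growth. Compound 1 `O=C(/C(=C/c1ccc(Cl)cc1)CCl)c1ccccc1` gives 17000 nM in this assay. Compound 2 `CC(=O)OC/C(=C\c1ccccc1)C(=O)c1ccccc1` gives 16000 nM in this assay, a number that lies within the usual scatter of the value of compound 1, so the two cannot be told apart on these data. Compound 3 `CC(=O)OC/C(=C\c1ccc(Cl)cc1)C(=O)c1ccccc1` has not yet been measured. It is built from compound 2 by chloro in place of hydrogen on an aromatic carbon, para to a large group. For the measured compounds named here, no pair of measured compounds isolates this change, so no measured step sets its size. Since compound 1 also carries that chloro group and gives 17000 nM, close to the value of compound 2, the change is not expected to move the number beyond the scatter. The step of a 1.1-fold lower number from compound 2 to compound 3 (0.06 log units; within the scatter) is expected to be small. Compound 3 is estimated at 14000 nM, with a range from 6000 nM to 35000 nM.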

Compound 3, concentration for 50% growth inhibition: 5300 nM
Compound 3: middle estimate off by 2.6-fold (0.42 log units), on the high side; measured number outside the range, below it.
By their numbers in this assay, from the lowest: compound 3; then compounds 2 and 1 (each within the scatter of the next).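

In this assay, the chloro group in place of hydrogen on the aromatic carbon gives a 3.0-fold lower number from compound 2 to compound 3 (0.48 log units; beyond the scatter) when the acetoxy group is kept, so this position does respond to phenyl to 4-chlorophenyl. Acetoxy in place of chloro on the saturated chain carbon gives a 3.2-fold lower number from compound 1 to compound 3 (0.51 log units; beyond the scatter) when the 4-chlorophenyl is kept, which shows that the lower number appears only where the two groups stand together in compound 3, while compound 1 and compound 2 each carry just one of them and cannot be told apart. No measurement shown here accounts for either step.

Going by these compounds, whether a bromo or a methoxy group at this aromatic position would act like chloro remains open. So does whether an amine or a hydroxyl group on the saturated chain carbon would keep the lower number.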